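This account rests on a few compounds, and the source may have more. Where it says the series, first, only, none or still open, it means among the compounds named here.

Measured so far:
- compound 1 `COc1ccc(-c2cc(/C=C/C(=O)c3ccc(N)cc3)[nH]n2)cc1`: 96%
- compound 2 `COc1cc(-c2cc(/C=C/C(=O)c3ccc(N)cc3)[nH]n2)cc(OC)c1OC`: 99%

In a functional assay on UACC-62 cells (Homo sapiens) for cytotoxicity, read by sulforhodamine B assay, with a stated time of 48 h, tested at 0.01 uM (on this read-out higher numbers stand for a weaker effect at the one concentration tested and lower numbers for a stronger effect), compound 1 gives 96% and compound 2 gives 99%. The two numbers lie within the usual scatter of each other, so compound 2 does not stand apart from compound 1; both show a weak effect at the single concentration tested.

Compound 3 `COc1ccc(-c2cc(/C=C/C(=O)c3ccc(N)cc3)[nH]n2)cc1OC` is not yet measured. It differs from compound 2 by hydrogen in place of methoxy on an aromatic carbon. With both measured compounds near the top of the scale, no step beyond the scatter is expected in this assay.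

The step from compound 2 to compound 3 is estimated at a number 2 percentage points lower from compound 2 to compound 3 (within the scatter). Compound 3 is expected to give 97%, in the range 88% to 103%.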

Compound 3, a percentage reported as activity, at one concentration (the size of the read-out at that concentration, not a potency): 99%
Beside the measured number, compound 3's estimate is 2 percentage points below it, within the range that was stated.
By their numbers in this assay, from the lowest: compounds 1, 2 and 3 (each within the scatter of the next).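

In this assay, hydrogen in place of methoxy on the aromatic carbon ortho to a methoxy group gives no change at the digits printed from compound 2 to compound 3 (within the scatter), while methoxy in place of hydrogen on an aromatic carbon gives a number 3 percentage points higher from compound 1 to compound 3 (within the scatter), so neither change separates the compounds at this single concentration. All three readings stay at the weak end of the scale, and this position shows no sensitivity to methoxy versus hydrogen here. No supporting measurement bears on this result.

On these data alone, whether a hydroxyl or an amine at this position would move the reading remains open. A single concentration also leaves open whether these compounds would show a stronger effect at other concentrations.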